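A few compounds are considered here, and "the series" means these few. Any claim that something is new, unique, unknown or untested is made for them only; others in the source may bear on it.

Three compounds share one core. Compound 1 `CNC(=O)c1cn(Cc2ccc(-c3ccccc3)cc2)c2c(OC)c(N3CC[C@@H](CN)C3)c(F)cc2c1=O` gives 82100 nM in an assay on isolated protein for inhibition of DNA topoisomerase 1 (Homo sapiens), with a stated time of 15 min (a lower number here means a stronger inhibitor, a higher number a weaker inhibitor), and compound 2 `COc1c(N2CC[C@@H](N)C2)c(F)cc2c(=O)c(C(=O)O)cn(Cc3ccc(-c4ccccc4)cc3)c12` gives 92200 nM in this assay. Compound 3 `O=C(O)c1cn(Cc2ccc(-c3ccccc3)cc2)c2cc(N3CC4CNCC4C3)c(F)cc2c1=O` gives 33300 nM in this assay, the lowest of the three numbers, beyond the scatter from compound 1 and from compound 2, so compound 3 stands as the strongest inhibitor of the measured set. Compound 4 `NCCNc1cc2c(cc1F)c(=O)c(C(=O)O)cn2Cc1ccc(-c2ccccc2)cc1` is not yet measured. From compound 3 it differs in one place: a group of 4 heavy atoms (2 carbon, 2 nitrogen; no ring) in place of a group of 8 heavy atoms (6 carbon, 2 nitrogen; 2 five-membered non-aromatic rings with 1 hetero atom each), on an aromatic carbon. Among the measured compounds shown here, no measured pair shows a change of this kind, so the size of the step is open; a modest weakening is expected rather than a gain, and the expected step is a 1.7-fold higher number from compound 3 to compound 4 (0.22 log units; within the scatter). Compound 4 is expected to give about 55000 nM in this assay, within a range from 15000 nM to 160000 nM.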

Compound 4, half-maximal inhibitory concentration: 72800 nM
For compound 4 the middle estimate is 1.3-fold (0.12 log units) below the measured one; low and high end bracket the measured number.
By their numbers in this assay, from the lowest: compound 3; then compounds 4, 1 and 2 (each within the scatter of the next).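

On the aromatic carbon ortho to a fluoro group, a first one-place comparison shows that this assay responds to the group held there: (2-aminoethyl)amino in place of the two-ring group gives a 2.2-fold higher number from compound 3 to compound 4 (0.34 log units; beyond the scatter). The step is modest, and the open chain retains measurable inhibition. Nothing at hand accounts for the step.

Open, from the compounds shown here alone, is how a longer chain such as 3-aminopropylamino, or a single-ring amine such as piperazine, would compare at this position. Also open, going by these compounds, is whether the step would carry over to the core of compound 1.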